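Amide series: three limits, one compound still open

This account rests on a few compounds, and the source may have more. Where it says the series, first, only, none or still open, it means among the compounds named here.

Measured compounds:
compound 1, `C=CC1=C(C(=O)NCc2ccc(Cl)cc2)C(c2ccc(F)cc2)OC1`, in a functional assay on SW480 cells (Homo sapiens) for cytotoxicity, read by MTT assay, with a stated time of 24 h (a lower number here means a stronger inhibitor, a higher number a weaker inhibitor), compound 1 gives > 100000 nM, a limit of the assay;
compound 2, `C=CC1=C(C(=O)NCCCCC)C(c2ccc(F)cc2)OC1`, compound 2 gives > 100000 nM, likewise a limit;
compound 3, `C=CC1=C(C(=O)NCc2ccc(Cl)cc2)C(c2ccc(OC)cc2)OC1`, compound 3 gives > 100000 nM, also a limit.

All three values sit at the same point, described by the limit of > 100000 nM in this assay, at which 3 of the 3 values shown sit. No number is read for any of them, so the steps between them carry no size. From compound 1 to compound 2 the change is butyl in place of 4-chlorophenyl on a saturated chain carbon bound to an amide-type nitrogen, and the step in this assay is a step that the two limits leave unreadable from compound 1 to compound 2. From compound 1 to compound 3 the cores differ by methoxy in place of fluoro on an aromatic carbon, and the step is a step that the two limits leave unreadable from compound 1 to compound 3.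

Compound 4, `C=CC1=C(C(=O)NCCCCC)C(c2ccc(OC)cc2)OC1`, is not yet measured. It differs from compound 3 by butyl in place of 4-chlorophenyl on a saturated chain carbon bound to an amide-type nitrogen; the place is the same as for the change from compound 1 to compound 2, so this is the same change made on the core of compound 3. Beside the step that the two limits leave unreadable from compound 1 to compound 2, the step from compound 3 to compound 4 in this assay is expected to be a step that the limit leaves unreadable from compound 3 to compound 4. Going by the values given here, that expectation rests on compound 1, compound 2 and compound 3 all sitting at the limit given by the limit of > 100000 nM in this assay, at which 3 of the 3 values shown sit, with nothing among the measured compounds pointing to a readable number.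

Compound 4 is therefore estimated at 200000 nM in this assay, with the range 100000 nM to 1000000 nM, most likely reported as a limit again.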

Compound 4, half-maximal inhibitory concentration: > 100000 nM
Compound 4 ended at the assay's limit (the forecaster's own chance of this, stated with the estimate: 85%); the middle value does not contradict the limit.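

In this assay compound 4 gives > 100000 nM, a limit of the assay. No new step can be read from compound 3 or compound 2 to compound 4, and compound 1 to compound 4 offers no comparison either, as all four compounds share one point: the limit of > 100000 nM in this assay, at which 4 of the 4 values shown sit.

The compounds shown leave open whether any amide substituent or aryl group on the shared core gives a readable number.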